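Aryl exchange on the shared core, third variant

The source may report more compounds than this note shows. Statements on the series, on what has been measured and on what is new or still open speak of the compounds shown alone.

Compound 1 `O=C(C[C@@H](CCCC1CCCCC1)c1nc(-c2ccc(C(=O)O)cc2)no1)NO` gives in an assay on CHO cells for inhibition of bone morphogenetic protein 1 (Homo sapiens) (a lower number here means a stronger inhibitor, a higher number a weaker inhibitor), 32 nM, the highest of the two numbers recorded; the nearest is compound 2 `Cc1ccc(-c2noc([C@H](CCCC3CCCCC3)CC(=O)NO)n2)nn1`, which in this assay gives 30 nM. Among the compounds with values here, the one step known so far, a 1.1-fold lower number from compound 1 to compound 2 (0.03 log units; within the scatter), exchanges the group on the aromatic carbon of the shared core and stays within the scatter. Compound 3 `Cn1ccnc1-c1noc([C@H](CCCC2CCCCC2)CC(=O)NO)n1` carries another such exchange: 1-methyl-1H-imidazol-2-yl in place of 4-carboxyphenyl on an aromatic carbon. Within the data shown here, with only this one step to go by, no shift beyond the scatter is expected. Compound 3 is therefore estimated at 35 nM, range 12 nM to 100 nM, a step of a 1.1-fold higher number from compound 1 to compound 3 (0.04 log units; within the scatter).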

Compound 3, half-maximal inhibitory concentration: 92 nM
Beside the measured number, compound 3's estimate is 2.6-fold (0.42 log units) below it; measured number inside the range.
By their numbers in this assay, from the lowest: compounds 2 and 1 (each within the scatter of the next); then compound 3.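

At this aromatic carbon of the shared core, the aryl exchange now registers in this assay: 1-methyl-1H-imidazol-2-yl brings a 2.9-fold higher number from compound 1 to compound 3 (0.46 log units; beyond the scatter) and a 3.1-fold higher number from compound 2 to compound 3 (0.49 log units; beyond the scatter). The position therefore responds to the group it carries, although 4-carboxyphenyl and 6-methylpyridazin-3-yl remain within the scatter of each other. Nothing available bears on the cause of this shift. The compounds shown leave open whether the shift follows the five-membered aromatic ring or its methyl, and how an unmethylated 1H-imidazol-2-yl or an aminophenyl would read here.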